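The source may hold more compounds than are shown below. What is called first, only, known or untested is meant among the compounds shown, and "the series" means these compounds.

Measured in a functional assay on A-375 cells (Homo sapiens) for inhibition, read by MTT assay, with a stated time of 5 days; on this read-out higher numbers stand for weaker inhibition and lower numbers for stronger inhibition:
- compound 1 `Nc1nccc(-c2sc(C3CCCCN3)nc2-c2cccc(NS(=O)(=O)c3cc(F)ccc3F)c2F)n1`: 5.12 nM
- compound 2 `CC(C)(C)c1nc(-c2cc(Cl)cc(NS(=O)(=O)c3cc(F)ccc3F)c2F)c(-c2ccnc(N)n2)s1`: 1.73 nM

Of these two numbers, compound 1 has the higher, at 5.12 nM. Compound 2 is lower at 1.73 nM, a gap beyond the usual scatter.

The open question is compound 3 `NCCCc1nc(-c2cccc(NS(=O)(=O)c3cc(F)ccc3F)c2F)c(-c2ccnc(N)n2)s1`. It keeps the core of compound 1 and carries 3-aminopropyl in place of piperidin-2-yl on an aromatic carbon.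

Among the measured compounds shown here, no measured pair isolates a change at this place, so there is no direct precedent for the step in this assay. For the measured compounds named here, the only guide is that compound 1, at 5.12 nM, and compound 2, at 1.73 nM, both give low numbers with different groups there, though they also differ elsewhere. A large loss is therefore not expected, and a small weakening is the working assumption. The estimated step is a modest rise, a 1.8-fold higher number from compound 1 to compound 3 (0.24 log units; within the scatter), and it is expected to stay close to the usual scatter. For compound 3 the expected value is 9 nM, with an estimated range of 2.5 nM to 35 nM.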

Compound 3, half-maximal inhibitory concentration: 39.5 nM
Compound 3: the middle estimate sits 4.4-fold (0.64 log units) below what was measured; the measured number lies above the stated range.
By their numbers in this assay, from the lowest: compound 2; then compound 1; then compound 3.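

The carbon of the five-membered aromatic ring next to the ring nitrogen and next to the ring sulfur is now shown to be sensitive to the group it carries: in this assay, 3-aminopropyl in place of piperidin-2-yl gives a 7.7-fold higher number from compound 1 to compound 3 (0.89 log units; beyond the scatter), the first reading of a change at this place alone. The two groups have the same hydrogen-bond donor and acceptor counts and no net charge, so those counts do not track the step; the listed differences are the six-membered non-aromatic ring of piperidin-2-yl, absent from 3-aminopropyl, and the heavy-atom count. No measurement is at hand that accounts for the size of the step.

The compounds shown leave open whether the step follows from the missing ring or from the length and shape of the chain, which a 4-aminobutyl or 2-aminoethyl chain would help separate. They also leave open whether the amine nitrogen matters at this place, which a plain propyl chain or a cyclohexyl ring, each without nitrogen, would test against 3-aminopropyl and piperidin-2-yl.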